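This account rests on a few compounds, and the source may have more. Where it says the series, first, only, none or still open, it means among the compounds named here.

Measured in a functional assay on KB cells (Homo sapiens) for antiproliferative activity, read by sulforhodamine B assay, with a stated time of 72 h; on this read-out lower numbers stand for stronger inhibition and higher numbers for weaker inhibition:
Compound 1 `O=C(/C=C/c1csc2ccccc12)c1ccccc1O`: 6200 nM
Compound 2 `O=C(/C=C/c1cc2ccccc2s1)c1cc(Cl)ccc1O`: > 10000 nM (a limit)
Compound 3 `O=C(/C=C/c1cc2ccccc2s1)c1cc(Br)ccc1O`: > 10000 nM (a limit)

Compound 2 has no number in this assay, only the limit > 10000 nM. Compound 3 also stands at a limit, > 10000 nM. Of the three, only compound 1 gives a number, 6200 nM. The series therefore shows (the limit of > 10000 nM in this assay, at which 2 of the 3 values shown sit), and compound 2 cannot be placed more closely than that.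

The next compound is compound 4 `O=C(/C=C/c1cc2ccccc2s1)c1cc(Cl)cc(Cl)c1O`, which differs from compound 2 by one change: chloro in place of hydrogen on an aromatic carbon. The entering chloro stands ortho to a hydroxy group and meta to a chloro group. Within the data shown here, the one measured step between close relatives is a step that the two limits leave unreadable from compound 2 to compound 3, with bromo in place of chloro on an aromatic carbon. Among the measured compounds shown here, that step has no size to carry over, and no measured step adds a chloro in place of hydrogen. No clear direction can therefore be expected in this assay, and another limit is the likeliest report. The expected step is a number no higher from compound 2 to compound 4 (the limit leaves the size open). For compound 4 the estimated value is 10000 nM, with an expected range from 4000 nM to 25000 nM.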

Compound 4, half-maximal inhibitory concentration: 7800 nM
Compound 4: the middle estimate sits 1.3-fold (0.11 log units) above what was measured; measured number inside the range.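

In this assay, chloro in place of hydrogen on an aromatic carbon, ortho to a hydroxy group and meta to a chloro group, gives an at least 1.2-fold lower number from compound 2 to compound 4 (0.10 log units; that floor lies within the scatter). Of compounds 2, 3 and 4, which share one core, compound 4 alone reads as a number rather than a limit, so this position accepts the added chloro with no rise in the number, though the floor of the step does not establish a real gain. Only that floor can be read because compound 2 stands at a limit: the limit of > 10000 nM in this assay, at which 2 of the 4 values shown sit.

The compounds shown leave open how large the step really is, and whether a bromo, methyl or methoxy group at this same position would read like chloro in this assay. They also leave open how an amine or a carboxylic acid would fare there, and whether the same added chloro would give a comparable step with bromo in place of the chloro group already present, as in compound 3.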